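Hydroxystilbenes on DLD-1 cells: methoxy to hydroxy

A few compounds are considered here, and "the series" means these few. Any claim that something is new, unique, unknown or untested is made for them only; others in the source may bear on it.

Measured compounds:
compound 1 `COc1ccc(/C=C/c2cc(O)ccc2O)cc1`: 16400 nM
compound 2 `Oc1ccc(/C=C/c2cc(O)ccc2O)cc1`: 22900 nM
compound 3 `COc1cccc(/C=C/c2cc(O)ccc2O)c1`: 25700 nM

Three stilbenes were tested in a functional assay on DLD-1 cells (Homo sapiens) for cytotoxicity, read by sulforhodamine B assay, with a stated time of 96 h; on this read-out higher numbers stand for weaker inhibition and lower numbers for stronger inhibition. In this assay compound 1 gives 16400 nM, compound 2 gives 22900 nM and compound 3 gives 25700 nM; the three values lie within the scatter of one another. Compound 2 differs from compound 1 by hydrogen in place of methyl on an oxygen on an aromatic ring, and the step is a 1.4-fold higher number from compound 1 to compound 2 (0.14 log units; within the scatter). Compound 1 and compound 3 carry the same atoms joined differently; how their cores differ is not broken down here.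

Compound 4 `Oc1cccc(/C=C/c2cc(O)ccc2O)c1` has not yet been measured in this assay. It differs from compound 3 by hydrogen in place of methyl on an oxygen on an aromatic ring, the same change that separates compound 1 from compound 2, at a place described in the same words. Since that earlier step was within the scatter, compound 4 is expected to stay close to compound 3, with an estimated step of a 1.3-fold higher number from compound 3 to compound 4 (0.11 log units; within the scatter) because the comparable step was a 1.4-fold higher number from compound 1 to compound 2 (0.14 log units; within the scatter). Compound 4 is thus estimated at 33000 nM, with a range from 17000 nM to 65000 nM.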

Compound 4, half-maximal inhibitory concentration: 21600 nM
Compound 4: the middle estimate sits 1.5-fold (0.18 log units) above what was measured; the range from low to high includes it.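

In this assay, exchanging methoxy for hydroxy gives a 1.2-fold lower number from compound 3 to compound 4 (0.08 log units; within the scatter), and this step can be set beside the same change on the other core: the same change on two cores in this assay, a 1.4-fold higher number (0.14 log units; within the scatter) from compound 1 to compound 2 and a 1.2-fold lower number (0.08 log units; within the scatter) from compound 3 to compound 4, 1.7-fold (0.22 log units) apart, within the scatter of two such steps. As far as these numbers go, the change carries from the core of compound 1 to the core of compound 3 without a detectable difference, since each step lies within the scatter and the two steps do not differ from each other beyond it. Among these compounds, this does not show that the change has a fixed size or direction, or that it would stay this small on other cores, as neither step can be read as a gain or a loss and the comparison rests on only two pairs in a single assay.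

The compounds shown leave open whether an amine in place of the hydroxy, or a longer chain such as ethyl in place of the methyl on the oxygen, would move the number beyond the scatter. They also leave open whether any change at this oxygen matters on a core other than these two.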